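A few compounds are considered here, and "the series" means these few. Any claim that something is new, unique, unknown or untested is made for them only; others in the source may bear on it.

Measured so far in a functional assay on BSC-1 cells (Cercopithecidae) for cytotoxicity; on this read-out higher numbers stand for weaker inhibition and lower numbers for stronger inhibition:

compound 1 `CSc1nc(Cl)c2ccn(COCCO)c2n1`: > 100000 nM
compound 2 `OCCOCn1ccc2c(Cl)nc(Cl)nc21`: > 100000 nM
compound 3 `Nc1nc(Cl)nc2c1ccn2COCCO`: > 100000 nM

The value of compound 1 is a limit of the assay and not a number. The value of compound 2 is likewise only a limit. The value of compound 3 is again a limit. Compound 2 therefore stands at the limit, with no number of its own, and the other two values shown sit at the same limit (the limit of > 100000 nM in this assay, at which 3 of the 3 values shown sit).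

Among the compounds with values here, two measured steps touch the core of compound 2. The step from compound 1 to compound 2 is a step that the two limits leave unreadable from compound 1 to compound 2, and the step from compound 2 to compound 3 is a step that the two limits leave unreadable from compound 2 to compound 3; neither can be read in size or direction, since both ends are limits.

Compound 4 `CC(=O)Nc1nc(Cl)c2ccn(COCCO)c2n1` differs from compound 2 by acetamido in place of chloro on an aromatic carbon. The two measured steps on this core, both unreadable, give no basis for expecting a readable step in this assay in either direction; the change at the same position from chloro to amino left compound 3 at the limit, and an acetamido group is expected to behave alike.

Compound 4 is therefore estimated at 100000 nM, with a range from 40000 nM to 300000 nM, most likely reported only as a limit. The expected step from compound 2 to compound 4 is a number no higher from compound 2 to compound 4 (the limit leaves the size open), none beyond the scatter.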

Compound 4, half-maximal inhibitory concentration: > 100000 nM
Compound 4 gave a limit, no number; the forecaster's own chance of this, stated with the estimate: 85%; the middle value lies on the limit itself.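

In this assay compound 4 gives > 100000 nM as a limit and not a number, so its steps from compound 1 and from compound 2 cannot be read. All the compounds shown stand at one value: the limit of > 100000 nM in this assay, at which 4 of the 4 values shown sit. The compounds shown leave open whether any change at this place on the shared core gives a measurable value in this read-out.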